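Adding phenyl to compound 2

The source may hold more compounds than are shown below. What is called first, only, known or untested is meant among the compounds shown, and "the series" means these compounds.

In a functional assay on DBTRG cells (Homo sapiens) for inhibition, read by a luciferase reporter, with a stated time of 24 h (on this read-out lower numbers stand for stronger inhibition and higher numbers for weaker inhibition), compound 1 (`O=C1c2ccccc2C(=O)N1C[C@H]1CC[C@H](C(=O)N2CCN(c3ccccc3)CC2)CC1`) gives > 30000 nM as a limit of the assay. Compound 2 (`O=C1CCNC(=O)N1C[C@H]1CC[C@H](C(=O)N2CCN(c3ccccc3)CC2)CC1`) gives > 30000 nM which is also a limit. Among the measured compounds shown here, compound 2 therefore has no number, and the series so far shows only the limit of > 30000 nM in this assay, at which 2 of the 2 values shown sit, with no measured step to draw on. Compound 3 (`O=C1CC(c2ccccc2)NC(=O)N1C[C@H]1CC[C@H](C(=O)N2CCN(c3ccccc3)CC2)CC1`) carries phenyl in place of hydrogen on a saturated ring carbon. The estimated step of an at least 6.0-fold lower number from compound 2 to compound 3 (0.77 log units; beyond the scatter) is expected as a gain in inhibition beyond the scatter, of uncertain size. Staying at the limit remains possible. For compound 3 the expected value is 5000 nM (estimated range 500 nM to 30000 nM).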

Compound 3, half-maximal inhibitory concentration in the DBTRG assay: 4760 nM
Compound 3: the middle estimate sits 1.1-fold (0.02 log units) above what was measured, within the range that was stated.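

Phenyl on this saturated ring carbon brings the series off the limit in the DBTRG assay, with an at least 6.3-fold lower number from compound 2 to compound 3 (0.79 log units; beyond the scatter). As far as these compounds go, because compound 2 gives only a limit there, the true size of this gain stays unknown. In a physicochemical assay for solubility, at pH 7.4 (a lower number here means a less soluble compound, a higher number a more soluble compound), compound 2 gives 242000 nM, and compound 3 gives 1000 nM. The same change also carries a large cost in the physicochemical assay: the measured solubility of compound 2, 242000 nM, and of compound 3, 1000 nM, a 240-fold lower number (2.38 log units; beyond the scatter)

Open, from the compounds shown here alone, is whether a methyl group or an amine at this ring carbon would hold the gain in the DBTRG assay with a smaller loss in the physicochemical assay.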